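The source may hold more compounds than are shown below. What is called first, only, known or untested is meant among the compounds shown, and "the series" means these compounds.

Compound 1 `COc1ccc(Cl)cc1C(=O)NCCC1CCN(S(=O)(=O)NC(=O)NC[C@@H]2C[C@@H]3CC[C@@H]2O3)CC1` was tested in a functional assay on the whole organism (blood) with Rattus norvegicus as the target, with stated times of 24 h and 1 h, at a dose of 5 mg/kg by the intraperitoneal route (on this read-out higher numbers stand for a stronger effect at the one dose given and lower numbers for a weaker effect), where compound 1 gives 30%. Within the data shown here, its only measured neighbour is compound 2 `COc1ccc(Cl)cc1C(=O)NCCC1CCN(S(=O)(=O)NC(=O)NN2CCCCCC2)CC1`, which carries a different group on an amide-type nitrogen; in this assay compound 2 gives 36%, and the step of a number 6 percentage points higher from compound 1 to compound 2 (within the scatter) is within the scatter, so compound 1 and compound 2 cannot be set apart on these numbers. Compound 3 `O=C(NC[C@@H]1C[C@@H]2CC[C@@H]1O2)NS(=O)(=O)N1CCC(CCNC(=O)c2cccc3c2OCCO3)CC1` differs from compound 1 elsewhere: 2,3-dihydro-1,4-benzodioxin-5-yl in place of 5-chloro-2-methoxyphenyl on a carbonyl carbon. Among the measured compounds shown here, no measured step touches the carbonyl carbon or either of these groups, and the one step that exists, from compound 1 to compound 2, concerns the amide-type nitrogen instead, so it offers no guide. With nothing pointing either way, compound 3 is expected to stay within the scatter of compound 1, that is, an estimated step of no change at the digits printed from compound 1 to compound 3 (within the scatter). Compound 3 is therefore estimated at 30%, with a range from 10% to 55%.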

Compound 3, a percentage reported as activity, at one dose (the size of the read-out at that dose, not a potency): 15%
Estimate against measurement, compound 3: 15 percentage points above; the measured number falls inside the stated range.
By their numbers in this assay, from the lowest: compound 3; then compounds 1 and 2 (each within the scatter of the next).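

Among these compounds, until now the only step, on the amide-type nitrogen, lay within the scatter, so no place on the shared core had yet been seen to move the read-out. In this assay, 2,3-dihydro-1,4-benzodioxin-5-yl in place of 5-chloro-2-methoxyphenyl on a carbonyl carbon gives a number 15 percentage points lower from compound 1 to compound 3 (beyond the scatter), so the group at this place can shift the number beyond the scatter, here downward. The change removes the chlorine and adds a six-membered non-aromatic ring in one move, and nothing measured here explains the drop.

Going by these compounds, a plain 2-methoxyphenyl group on the same carbonyl carbon would help to separate the part of the chlorine from that of the added ring, and this remains open. Also open, on these data alone, is whether the same replacement would lower the number on the seven-membered ring of compound 2.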